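The source may hold more compounds than are shown below. What is called first, only, known or untested is meant among the compounds shown, and "the series" means these compounds.

Compound 1 `Cc1ccc(NC(=O)CN2CCN(c3nnc(Cc4ccncc4)c4ccccc34)CC2)c(C)c1`: 240 nM in a functional assay on MDA-MB-231 cells (Homo sapiens) for cytotoxicity, read by MTT assay, with a stated time of 72 h; a higher number here means a weaker inhibitor, a lower number a stronger inhibitor
Compound 2 `O=C(CN1CCN(c2nnc(Cc3ccncc3)c3ccccc23)CC1)Nc1ccc(F)c(C(F)(F)F)c1`: 1.9 nM in this assay

Among the compounds with values here, compound 2 holds the lowest of the two numbers, and the only measured step, a 130-fold lower number from compound 1 to compound 2 (2.10 log units; beyond the scatter), is large. Compound 3 `O=C(CN1CCN(c2nnc(Cc3ccncc3)c3ccccc23)CC1)Nc1ccc(F)c(F)c1` differs from compound 2 by fluoro in place of trifluoromethyl on an aromatic carbon. That single step exchanged the whole aryl group, so it bears on this change only loosely, though it shows the amide-bound aryl to matter greatly. Losing the trifluoromethyl is expected to cost some potency, a step of a 4.2-fold higher number from compound 2 to compound 3 (0.62 log units; beyond the scatter) in this assay. Compound 3 is therefore estimated at 8 nM, within 2 nM to 40 nM.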

Compound 3, half-maximal inhibitory concentration: 0.84 nM
Compound 3: middle estimate off by 9.5-fold (0.98 log units), on the high side; the measured number lies below the stated range.
By their numbers in this assay, from the lowest: compound 3; then compound 2; then compound 1.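

In this assay, trifluoromethyl proves unnecessary at this position: fluoro in its place gives a 2.3-fold lower number from compound 2 to compound 3 (0.35 log units; beyond the scatter), a modest gain rather than a loss. The large difference from the 2,4-dimethylphenyl amide also persists without trifluoromethyl, with a 290-fold lower number from compound 1 to compound 3 (2.46 log units; beyond the scatter). No measurement at hand accounts for this order.

The compounds shown leave open whether chloro, methoxy or nitrile in the same place would match fluoro. They also leave open whether the remaining fluoro group is needed, as a plain 3-fluorophenyl or unsubstituted phenyl would show.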